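Cyano in Place of Fluoro on the Amide Aryl Ring

The source may report more compounds than this note shows. Statements on the series, on what has been measured and on what is new or still open speak of the compounds shown alone.

Measured compounds:
Compound 1, `O=C(Nc1ccnnc1)c1cc(N2C[C@H]3COC[C@H]3C2)ccc1OCc1ccccc1`: 50.1 nM
Compound 2, `O=C(Nc1cccc(F)c1)c1cc(C(F)(F)F)ccc1OCc1ccc(F)cc1`: 31.6 nM

Both compounds were tested in an assay on Sf9 cells for inhibition of Leucine-rich repeat serine/threonine-protein kinase 2 (Homo sapiens), read by TR-FRET, with stated times of 30 min and 2 h; a lower number here means a stronger inhibitor, a higher number a weaker inhibitor. In this assay compound 1 gives 50.1 nM, and compound 2 gives 31.6 nM. Compound 2 has the lowest of the two numbers, but the gap to compound 1 lies within the usual scatter of repeated measurements, so the two cannot be told apart by strength. The two compounds also differ in several places at once, so no single structural change can be read from their pair.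

Compound 3, `N#Cc1cccc(NC(=O)c2cc(C(F)(F)F)ccc2OCc2ccc(F)cc2)c1`, has not been measured. It differs from compound 2 in one place only: cyano in place of fluoro on an aromatic carbon. Among the measured compounds shown here, no step between measured compounds shows what this kind of change does, so any expectation rests on compound 2 alone. Because compound 2 gives 31.6 nM in this assay, compound 3 is expected to land close to it. For compound 3 the estimate is 35 nM, with a range from 12 nM to 100 nM. That estimate means an expected step of a 1.1-fold higher number from compound 2 to compound 3 (0.04 log units; within the scatter), not beyond the scatter in either direction.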

Compound 3, half-maximal inhibitory concentration: 7.94 nM
Beside the measured number, compound 3's estimate is 4.4-fold (0.64 log units) above it; measured number outside the range, below it.
By their numbers in this assay, from the lowest: compound 3; then compounds 2 and 1 (each within the scatter of the next).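

Among the compounds shown here, this is the first step between measured compounds that differ in one place, and it shows that what sits at this position matters: going from 3-fluorophenyl to 3-cyanophenyl gives a 4.0-fold lower number from compound 2 to compound 3 (0.60 log units; beyond the scatter) in this assay and so a stronger inhibitor. The position therefore takes the larger group without any loss of strength, as cyano brings two heavy atoms where fluoro brings one. Cyano also brings a triple bond and one hydrogen-bond acceptor where fluoro has neither, but nothing at hand says which of these differences matters, or why the number falls. 

For the compounds shown here, a single step cannot show whether cyano would give a similar shift on a different core, such as the one in compound 1, which carries neither of these two groups. It also leaves open how other groups at this same position would compare, for instance an amine, a methoxy group or a carboxylic acid, and whether any of them would go beyond cyano or fall back towards fluoro.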